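Oxetane to Tertiary Alcohol: an Expected Potency for Compound 3

A few compounds are considered here, and "the series" means these few. Any claim that something is new, unique, unknown or untested is made for them only; others in the source may bear on it.

Compound 1 `Cc1nn(C2COC2)cc1Nc1nc(N)c2c(C#N)c(N3CCC[C@H]3C)n(C)c2n1`: 25 nM
Compound 2 `Cc1nn(C2CCOC2)cc1Nc1nc(N)c2c(C#N)c(N3CCC[C@H]3C)n(C)c2n1`: 12 nM; 28 nM (2 entries)

Within the data shown here, in an assay on isolated protein for inhibition of Leucine-rich repeat serine/threonine-protein kinase 2 variant G2019S (Homo sapiens), read by TR-FRET and LanthaScreen, with stated times of 50 min and 30 min, in the presence of a further agent that is not named here (a lower number here means a stronger inhibitor, a higher number a weaker inhibitor), compound 1 gives 25 nM, the only number it has there. Compound 2 gives 12 nM; 28 nM (2 entries), and its repeated entries (the several entries of compound 2 in this assay, 12 nM; 28 nM (2 entries)) show how far repeats of this kind drift apart; the values of compound 1 and compound 2 lie within that scatter of each other. Compound 3 `Cc1nn(CC(C)(C)O)cc1Nc1nc(N)c2c(C#N)c(N3CCC[C@H]3C)n(C)c2n1` differs from compound 1 by 2-hydroxy-2-methylpropyl in place of oxetan-3-yl on an aromatic nitrogen. Among the measured compounds shown here, no measured pair shows this change, so the expected step is a 1.1-fold lower number from compound 1 to compound 3 (0.06 log units; within the scatter), nothing beyond the scatter in either direction. Compound 3 is therefore estimated at 22 nM, with a range from 8 nM to 60 nM.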

Compound 3, half-maximal inhibitory concentration: 42 nM
The estimate for compound 3 lay 1.9-fold (0.28 log units) below the measured number, and the stated range covers the measured number.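

In this assay, the step from the ring-bearing oxetan-3-yl to the open 2-hydroxy-2-methylpropyl on the aromatic nitrogen gives a 1.7-fold higher number from compound 1 to compound 3 (0.23 log units; within the scatter). At this position, then, a group with no ring and with a hydrogen-bond donor gives a number that cannot be told apart from that of compound 1, given how far repeats drift: the several entries of compound 2 in this assay, 12 nM; 28 nM (2 entries)

The compounds shown leave open how an amine or a carboxylic acid would read on this nitrogen. They also leave open whether a longer chain ending in a hydroxyl would stay within the scatter.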